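From 3-nitrophenyl to 4-chlorophenyl at an assay limit

The compounds below may be only part of what the source reports. "The series", "measured", "known", "first", "only" and "open" are said of these compounds alone.

In a functional assay on U-251 cells (Homo sapiens) for inhibition, read by MTT assay, with a stated time of 2 days (a higher number here means that more compound is tolerated, a lower number that less compound is tolerated), compound 2 `Nc1ccccc1NC(=O)c1ccc(NCC(=O)Nc2cccc([N+](=O)[O-])c2)cc1` gives > 100000 nM, which is a limit and not a number. Compound 1 `Nc1ccccc1NC(=O)CCCNCC(=O)Nc1ccc(Br)cc1` gives > 100000 nM, again a limit. Compound 3 `Nc1ccccc1NC(=O)CCCNCC(=O)Nc1ccccc1Cl` gives > 100000 nM, also a limit. So compound 2 has no measured position among its neighbours, and the record so far is the limit of > 100000 nM in this assay, at which 3 of the 3 values shown sit.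

The change to compound 4 `Nc1ccccc1NC(=O)c1ccc(NCC(=O)Nc2ccc(Cl)cc2)cc1` is 4-chlorophenyl in place of 3-nitrophenyl on an amide-type nitrogen. The closest measured precedent also exchanges the group on an amide-type nitrogen, but it is a step that the two limits leave unreadable from compound 1 to compound 3. It therefore gives no size or direction to carry over, and no step beyond the usual scatter can be expected in this assay. The step expected here is a number no higher from compound 2 to compound 4 (the limit leaves the size open), and this estimate is a placeholder for no real change. For compound 4 the estimated value is 100000 nM, with an expected range from 40000 nM to 200000 nM, and the assay may well report only a limit again.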

Compound 4, concentration lethal to 50% of the cells: > 100000 nM
Compound 4: no number, only a limit (the forecaster's own chance of this, stated with the estimate: 75%); the middle value sits exactly at the limit.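

In this assay compound 4 gives > 100000 nM, a limit and not a number, and compound 2 also stands at a limit, so no step can be read between them: the limit of > 100000 nM in this assay, at which 4 of the 4 values shown sit.

On these data alone, whether 4-chlorophenyl in place of 3-nitrophenyl changes anything in this assay stays open.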